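Notes on a Methoxy Step Across Two Cores

A few compounds are considered here, and "the series" means these few. Any claim that something is new, unique, unknown or untested is made for them only; others in the source may bear on it.

In a functional assay on ECa-109 cells (Homo sapiens) for cytotoxicity, read by MTT assay, with a stated time of 72 h (a lower number here means a stronger inhibitor, a higher number a weaker inhibitor), the measured compounds give:
compound 1 `O=C1C(=Cc2ccc(O)cc2)C(=O)N(c2ccc(Cl)cc2)N1c1ccc(Cl)cc1`: 34200 nM
compound 2 `COc1cc(C=C2C(=O)N(c3ccc(Cl)cc3)N(c3ccc(Cl)cc3)C2=O)ccc1O`: 7100 nM
compound 3 `COc1cccc(C=C2C(=O)N(c3ccc(Cl)cc3)N(c3ccc(Cl)cc3)C2=O)c1`: 29000 nM

The change methoxy in place of hydrogen on an aromatic carbon produced the step of a 4.8-fold lower number from compound 1 to compound 2 (0.68 log units; beyond the scatter). The cores of compound 1 and compound 3 differ by 3-methoxyphenyl in place of 4-hydroxyphenyl on a double-bonded chain carbon bound to a double-bonded ring carbon, and a 1.2-fold lower number from compound 1 to compound 3 (0.07 log units; within the scatter) lies within the scatter. Compound 4 `COc1ccc(C=C2C(=O)N(c3ccc(Cl)cc3)N(c3ccc(Cl)cc3)C2=O)cc1OC` is unmeasured and differs from compound 3 by methoxy in place of hydrogen on an aromatic carbon. This is the same kind of change as that between compound 1 and compound 2, not the same: there the entering group sat ortho to a hydroxy group (1 heavy atom) and meta to a large group, here it sits ortho to a methoxy group (2 heavy atoms) and para to a large group. Within the data shown here, a smaller step is expected for compound 4, a 1.9-fold lower number from compound 3 to compound 4 (0.29 log units; within the scatter), resting on the single precedent a 4.8-fold lower number from compound 1 to compound 2 (0.68 log units; beyond the scatter) and the altered surroundings. The estimate for compound 4 in this assay is 15000 nM, between 5000 nM and 40000 nM.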

Compound 4, half-maximal inhibitory concentration: > 128000 nM
Compound 4 was reported as a limit (the forecaster's own chance of this, stated with the estimate: 5%); at least 8.5-fold (0.93 log units) between middle value and limit.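

Methoxy in place of hydrogen on an aromatic carbon does not carry over from one core to the other in this assay: the same change on two cores in this assay, a 4.8-fold lower number (0.68 log units; beyond the scatter) from compound 1 to compound 2 and an at least 4.4-fold higher number (0.64 log units; beyond the scatter) from compound 3 to compound 4, at least 21-fold (1.32 log units) apart, beyond the scatter of two such steps.

Compound 4 is reported only as a limit and not as a number: the limit of > 128000 nM in this assay, at which 1 of the 4 values shown sits.

The new steps, an at least 4.4-fold higher number from compound 3 to compound 4 (0.64 log units; beyond the scatter) and an at least 18-fold higher number from compound 2 to compound 4 (1.25 log units; beyond the scatter) and an at least 3.7-fold higher number from compound 1 to compound 4 (0.57 log units; beyond the scatter), are therefore bounds, so they fix the direction but not the full size, and two cores do not show which difference in surroundings decides that direction.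

Open, going by these compounds, is whether the free hydroxy group of compound 2 can be replaced by an amine or a carboxylic acid with the step preserved. Also open, on these data alone, is how ethoxy or a longer chain would behave in place of either methoxy group of compound 4.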